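Swapping the dichlorophenyl of compound 2 for a methoxyphenyl

The source may hold more compounds than are shown below. What is called first, only, known or untested is meant among the compounds shown, and "the series" means these compounds.

Measured compounds:
Compound 1, `O=C(N/N=C/c1ccc(F)cc1)Nc1ccc(Oc2ccnc3[nH]ccc23)c(F)c1`: 3880 nM
Compound 2, `O=C(N/N=C/c1cccc(Cl)c1Cl)Nc1ccc(Oc2ccnc3[nH]ccc23)c(F)c1`: "not active" (no number reported)

Both compounds share a core and differ only in the aromatic ring hanging from the carbon that is double-bonded to nitrogen. In a functional assay on HepG2 cells (Homo sapiens) for antiproliferative activity, read by MTT assay, with a stated time of 72 h (a lower number here means a stronger inhibitor, a higher number a weaker inhibitor), compound 1 gives 3880 nM. For compound 2, this assay reports "not active" (no number reported) and no number, so compound 2 cannot be placed on a scale at all; it simply did not show measurable inhibition in this test.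

Compound 3, `COc1ccc(/C=N/NC(=O)Nc2ccc(Oc3ccnc4[nH]ccc34)c(F)c2)cc1`, is the next compound to be measured. It differs from compound 2 by 4-methoxyphenyl in place of 2,3-dichlorophenyl on a carbon with a double bond to nitrogen

Because compound 1 shows 3880 nM with a different single substituent on that same ring, the expectation is that compound 3 returns to a measurable value rather than staying without activity like compound 2, which amounts to a gain over compound 2 in this assay of unknown size. The estimate for compound 3 in this assay is 4000 nM, with a plausible range from 1200 nM to 15000 nM, and a real chance it is again reported as not active.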

Compound 3, half-maximal inhibitory concentration: 1770 nM
For compound 3 the middle estimate is 2.3-fold (0.35 log units) above the measured one, within the range that was stated.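

In this assay, compound 3 with its 4-methoxyphenyl gives 1770 nM, while compound 2 with its 2,3-dichlorophenyl on the same carbon with a double bond to nitrogen has no number. The change between these two compounds has no size that can be read. Methoxy in place of fluoro on an aromatic carbon gives a 2.2-fold lower number from compound 1 to compound 3 (0.34 log units; beyond the scatter), which shows that the choice of a single group on this ring also shifts the value by a modest amount beyond the scatter. The compounds shown give no measured property that could explain either difference.

The compounds shown leave open whether compound 2 lacks a number for having two chlorine atoms on the ring or for where those atoms sit, which a phenyl ring carrying a single chlorine could begin to separate. They also leave open how far the trend from fluoro to methoxy extends, for instance to an ethoxy group, an amine or a carboxylic acid on the ring.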